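A few compounds are considered here, and "the series" means these few. Any claim that something is new, unique, unknown or untested is made for them only; others in the source may bear on it.

In a functional assay on HepG2 cells (Mus musculus) for antiproliferative activity against HepG2 (Homo sapiens), read by MTT assay, with a stated time of 48 h (on this read-out higher numbers stand for weaker inhibition and lower numbers for stronger inhibition), compound 1 (`COc1cc(/C=C/c2nnc(NC(=O)c3ccc(Br)cc3)s2)c(Br)c(OC)c1OC`) gives 200 nM. Two relatives were measured alongside it: compound 2 (`COc1cccc(C(=O)Nc2nnc(/C=C/c3cc(OC)c(OC)c(OC)c3)s2)c1`) gives 270 nM, and compound 3 (`COc1cccc(/C=C/c2nnc(NC(=O)c3cc(OC)c(OC)c(OC)c3Br)s2)c1`) gives 210 nM. Compound 1 therefore stands level with both, its value lying within the usual scatter of each, and the three cannot be ranked on these numbers. These compounds differ from one another in more than one place, so no measured single change is available as a guide.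

Compound 4 (`COc1cc(/C=C/c2nnc(NC(=O)c3ccccc3)s2)c(Br)c(OC)c1OC`) departs from compound 1 in one place only: hydrogen in place of bromo on an aromatic carbon. This puts hydrogen in place of bromo on an aromatic carbon, para to a large group, so that the 4-bromophenyl becomes phenyl. The data hold no direct measure of this exchange. The nearest hint is compound 2, which carries no bromo at all and still gives 270 nM. A large loss of activity therefore seems unlikely. In this assay the expected outcome is a small move toward a higher number, a 1.4-fold higher number from compound 1 to compound 4 (0.15 log units; within the scatter), probably not beyond the scatter. For compound 4 the estimated value is 280 nM, with an expected range from 120 nM to 650 nM.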

Compound 4, half-maximal inhibitory concentration: 180 nM
Estimate against measurement, compound 4: 1.6-fold (0.19 log units) above; the measured number falls inside the stated range.
By their numbers in this assay, from the lowest: compounds 4, 1, 3 and 2 (each within the scatter of the next).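

Replacing 4-bromophenyl by phenyl gives a 1.1-fold lower number from compound 1 to compound 4 (0.05 log units; within the scatter) in this assay. Going by these compounds alone, this is the first single change that can be read directly, and it shows that at this place, para to a large group, the bromo can give way to hydrogen with the number staying within the scatter. The earlier compounds offered only a loose hint on this point, as they differ from one another in more than one place, and nothing available here accounts for the result.

The compounds shown leave open whether this place accepts anything other than bromo and hydrogen, such as an amine, a carboxylic acid or a longer chain, since only this one exchange can be read there. They also leave open what the bromo that compound 4 still carries on its other aromatic ring contributes, and whether removing it would give a step as small as this one or a step beyond the scatter.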